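Maximal response in the shared core: aryl swap at the pendant ring

A few compounds are considered here, and "the series" means these few. Any claim that something is new, unique, unknown or untested is made for them only; others in the source may bear on it.

Measured so far:
Compound 1, `COc1cccc(-c2ccc([C@H]3S[C@@H](C)C(=O)Nc4c3c(C)nn4-c3ccccc3C)cc2)c1`, gives 41% in an assay on isolated protein for agonist activity at Bile acid receptor (Homo sapiens), read by AlphaScreen, with a stated time of 30 min; a lower number here means a smaller maximal response, a higher number a larger maximal response.
Compound 2, `Cc1nn(-c2ccccc2C(F)(F)F)c2c1C(c1ccc(Oc3ccccc3)cc1)SC(C)C(=O)N2`, gives 50% in this assay.
Compound 3, `Cc1nn(-c2ccccc2F)c2c1C(c1ccc(Oc3ccccc3)cc1)SC(C)C(=O)N2`, gives 72% in this assay.

Compound 1 has the smallest of the three values. Its gap to compound 2 is within the usual scatter, so the two cannot be separated on these numbers; only compound 3 stands clearly apart from compound 1. Among the compounds with values here, the single step among the measured compounds, a number 22 percentage points higher from compound 2 to compound 3 (beyond the scatter), concerns the group on the aryl attached to the ring nitrogen of the shared core and not the pendant aryl at the other end.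

Compound 4, `Cc1ccccc1-n1nc(C)c2c1NC(=O)[C@H](C)S[C@@H]2c1ccc(-c2ccco2)cc1`, differs from compound 1 as follows: furan-2-yl in place of 3-methoxyphenyl on an aromatic carbon. Within the data shown here, no measured pair varies this position, so nothing speaks directly to the size or direction of the change. The working expectation is therefore no step beyond the scatter; compound 4 is estimated at 45%, with a range from 25% to 70%. The expected step is a number 4 percentage points higher from compound 1 to compound 4 (within the scatter), kept small for lack of any precedent at this position in this assay.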

Compound 4, largest response reached (reported as efficacy), in percent of the reference or control that the assay uses: 32%
Beside the measured number, compound 4's estimate is 13 percentage points above it; the measured number falls inside the stated range.
By their numbers in this assay, from the lowest: compounds 4, 1 and 2 (each within the scatter of the next, the first and the last beyond it); then compound 3.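

In this assay, within the data shown here, the first pair that varies this position gives a number 9 percentage points lower from compound 1 to compound 4 (within the scatter). On an aromatic carbon para to a large group, a five-membered aromatic ring with 1 hetero atom and 5 heavy atoms therefore cannot be separated from a six-membered aromatic ring of carbon only with 8 heavy atoms; both groups have 0 hydrogen-bond donors and 1 hydrogen-bond acceptor. Among these compounds, the earlier step concerned only the aryl on the ring nitrogen of the shared core, so this pair is the first direct reading at the pendant end of the series, and no information is available to explain the outcome.

Going by these compounds, a single pair within the scatter does not show whether this position is generally insensitive, and the response with an aminomethyl group or a carboxylic acid on the pendant aryl remains open. On these data alone, it is also open whether fluoro in place of methyl on the aryl at the ring nitrogen would change the maximal response when furan-2-yl is held at the pendant end.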